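A few compounds are considered here, and "the series" means these few. Any claim that something is new, unique, unknown or untested is made for them only; others in the source may bear on it.

Compound 1 `CN1CCN(CCNCc2cn(-c3ccc(F)cc3F)nc2-c2ccc(OC(F)(F)F)cc2)CC1` and compound 2 `Cc1ccccc1-c1nn(-c2ccc(F)cc2F)cc1CNCCN1CCN(C)CC1` share the same core and differ only in one aromatic group. In an ADME assay on Huh-7 cells (Homo sapiens) for cytotoxicity (a lower number here means that less compound is tolerated, a higher number that more compound is tolerated), compound 1 gives 18000 nM. For compound 2 the result in this assay is only a limit of the assay, > 20000 nM, so its true number is not known. For the measured compounds named here, the one measured step, an at least 1.1-fold higher number from compound 1 to compound 2 (0.04 log units; that floor lies within the scatter), is thus only a floor; what is certain is the limit of > 20000 nM in this assay, at which 1 of the 2 values shown sits. Compound 3 `CN1CCN(CCNCc2cn(-c3ccc(F)cc3F)nc2-c2ccc(S(=O)(=O)N(C)C)cc2)CC1` is the next compound to be measured. Its difference from compound 2 is 4-(dimethylsulfamoyl)phenyl in place of 2-methylphenyl on an aromatic carbon. Going by the values given here, no measured step covers this exchange: the only step available concerned a different pair of groups and stayed within the scatter, leaving both measured compounds near the upper end of what this assay reports. Compound 3 is expected to behave in the same way, with a step of a number no higher from compound 2 to compound 3 (the limit leaves the size open) that is expected to lie within the scatter. The estimate for compound 3 is 20000 nM, with a range from 8000 nM to 50000 nM, and a fair chance that this assay again reports only a limit.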

Compound 3, half-maximal cytotoxic concentration: > 20000 nM
Compound 3 was reported as a limit; the forecaster's own chance of this, stated with the estimate: 55%; the middle value sits exactly at the limit.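

Unlike 2-methylphenyl, the 4-(dimethylsulfamoyl)phenyl group carries hydrogen-bond acceptors and more heavy atoms, yet in this assay compound 3 again gives only a limit, > 20000 nM. Exchanging trifluoromethoxy for dimethylsulfamoyl gives an at least 1.1-fold higher number from compound 1 to compound 3 (0.04 log units; that floor lies within the scatter), which is only a floor, and the step between the two limits cannot be read. Three quite different groups at this position have therefore given no reading of a lower tolerated concentration, and the results now gather at a single limit: the limit of > 20000 nM in this assay, at which 2 of the 3 values shown sit.

Going by these compounds, the true numbers of compound 2 and compound 3 remain unknown, so any order among the three compounds stays open. On these data alone, it is also open whether a group of another kind at this position, such as a carboxylic acid or a primary amine on the phenyl ring, or a cyclohexyl ring in place of the phenyl ring, would give a clearly lower number in this assay.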